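A few compounds are considered here, and "the series" means these few. Any claim that something is new, unique, unknown or untested is made for them only; others in the source may bear on it.

Measured in a functional assay on ACHN cells (Homo sapiens); on this read-out higher numbers stand for weaker inhibition of growth and lower numbers for stronger inhibition of growth:
- Compound 1 `O=S(=O)(/C=C/c1ccc(C(F)(F)F)cc1F)Cc1ccc(Nc2ncnc3ccccc23)cc1`: 100000 nM
- Compound 2 `O=S(=O)(/C=C/c1ccc(Cl)cc1Cl)Cc1ccc(Nc2ncnc3ccc(Br)cc23)cc1`: 100 nM

Compound 2, at 100 nM, has the lower of the two numbers, and its gap to compound 1 lies well beyond the scatter. Compound 3 `O=S(=O)(/C=C/c1ccc(C(F)(F)F)cc1F)Cc1ccc(Nc2ncnc3ccc(Br)cc23)cc1` changes one group of compound 2: 2-fluoro-4-(trifluoromethyl)phenyl in place of 2,4-dichlorophenyl on a double-bonded chain carbon bound to a double-bonded chain carbon. Compound 1 carries the same incoming group at 100000 nM, but its core also differs from that of compound 3, so the data cannot show how much of the gap belongs to this group. A moderate rise toward weaker inhibition of growth is expected, an estimated 3.0-fold higher number from compound 2 to compound 3 (0.48 log units; beyond the scatter). The estimate for compound 3 is 300 nM, with an expected range of 50 nM to 5000 nM.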

Compound 3, concentration for 50% growth inhibition: 16000 nM
Compound 3: the middle estimate sits 53-fold (1.73 log units) below what was measured; measured number above the stated range.
By their numbers in this assay, from the lowest: compound 2; then compound 3; then compound 1.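

With the bromo core held fixed, the group on the double-bonded chain carbon matters far more than the first two compounds could show: 2-fluoro-4-(trifluoromethyl)phenyl in place of 2,4-dichlorophenyl gives a 160-fold higher number from compound 2 to compound 3 (2.20 log units; beyond the scatter), meaning much weaker inhibition of growth. With that same group in place, bromo instead of hydrogen on an aromatic carbon gives a smaller change, a 6.3-fold lower number from compound 1 to compound 3 (0.80 log units; beyond the scatter). Nothing available explains either step.

Whether the fluoro or the trifluoromethyl accounts for the loss remains open, as does the size of the bromo effect alongside 2,4-dichlorophenyl. A phenyl ring carrying a single chloro or a methoxy group could help separate these contributions.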